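The source may hold more compounds than are shown below. What is called first, only, known or untested is meant among the compounds shown, and "the series" means these compounds.

Among the compounds with values here, compound 3, `O=C(CCCCCCc1ccccc1)c1ncc(-c2ccc([N+](=O)[O-])cc2)o1`, is one of three compounds measured so far in an assay (Rattus norvegicus) for inhibition of Fatty-acid amide hydrolase 1 (Homo sapiens); a lower number here means a stronger inhibitor, a higher number a weaker inhibitor. Compound 1, `COC(=O)c1ccccc1-c1cnc(C(=O)CCCCCCc2ccccc2)o1`, gives 60 nM in this assay, and compound 2, `COC(=O)c1cccc(-c2cnc(C(=O)CCCCCCc3ccccc3)o2)c1`, gives 12 nM. Compound 3 gives 50 nM; this is the second highest of the three numbers, within the scatter of compound 1 and beyond the scatter of compound 2, whose number is lower. Compound 4, `N#Cc1ccc(-c2cnc(C(=O)CCCCCCc3ccccc3)o2)cc1`, is not yet measured. It differs from compound 3 in one place: cyano in place of nitro on an aromatic carbon. Within the data shown here, no single-change step between measured compounds is available here, so the expectation rests on the change alone. Compound 4 is expected to give about 45 nM, with a range from 15 nM to 130 nM. The step of a 1.1-fold lower number from compound 3 to compound 4 (0.05 log units; within the scatter) is expected to stay within the scatter.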

Compound 4, inhibition constant: 40 nM
The estimate for compound 4 lay 1.1-fold (0.05 log units) above the measured number; low and high end bracket the measured number.
By their numbers in this assay, from the lowest: compound 2; then compounds 4, 3 and 1 (each within the scatter of the next).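

Across the 4-nitrophenyl to 4-cyanophenyl change, this assay shows a 1.3-fold lower number from compound 3 to compound 4 (0.10 log units; within the scatter), the first single-change step available among these compounds. At this place, on an aromatic carbon para to a large group, cyano can therefore stand in for nitro with no change beyond the scatter. Nothing in hand accounts for this closeness.
As far as these compounds go, whether an amine or a carboxylic acid at this same place would also stay within the scatter of compound 3 remains open. So does whether the step between cyano and nitro would hold with a shorter chain on the carbonyl.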